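Alkyl chain extension in a series at the assay limit

This account rests on a few compounds, and the source may have more. Where it says the series, first, only, none or still open, it means among the compounds named here.

Compound 1 `CCSC(=S)N[C@H]1CCOC1=O`: in a functional assay on EC9706 cells (Homo sapiens) for cytotoxicity, read by MTT assay, with a stated time of 72 h (on this read-out higher numbers stand for weaker inhibition and lower numbers for stronger inhibition), compound 1 gives > 128000 nM, a limit of the assay.
Compound 2 `CCCCSC(=S)N[C@H]1CCOC1=O`: in this assay compound 2 gives > 128000 nM, a limit of the assay.
Compound 3 `CCCCCCSC(=S)N[C@H]1CCOC1=O`: in this assay compound 3 gives > 128000 nM, a limit of the assay.

Compound 3 stands at the limit where every value of the series sits (the limit of > 128000 nM in this assay, at which 3 of the 3 values shown sit). The measured steps a step that the two limits leave unreadable from compound 1 to compound 2, a step that the two limits leave unreadable from compound 1 to compound 3 and a step that the two limits leave unreadable from compound 2 to compound 3 are unreadable, the limits on both sides hiding any size. Compound 4 `CCCCCCCCSC(=S)N[C@H]1CCOC1=O` differs from compound 3 by ethyl in place of hydrogen on a saturated chain carbon, six bonds along the chain from a sulfur. For the measured compounds named here, no measured step supplies a readable size, so in this assay no direction beyond the scatter can be expected from chain extension. The expected step is a step that the limit leaves unreadable from compound 3 to compound 4. Compound 4 is expected to give 150000 nM, within 60000 nM to 400000 nM, most likely reported again as a limit.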

Compound 4, half-maximal inhibitory concentration: > 128000 nM
Compound 4: no number, only a limit; the forecaster's own chance of this, stated with the estimate: 85%; the middle value is on the limit's open side.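

No new step can be read among compound 1, compound 2, compound 3 and compound 4, since each value is a limit in this assay: the limit of > 128000 nM in this assay, at which 4 of the 4 values shown sit.

The compounds shown leave open whether any alkyl chain on this core gives a readable value in this assay.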